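A second propyl on the amide nitrogen

The compounds below may be only part of what the source reports. "The series", "measured", "known", "first", "only" and "open" are said of these compounds alone.

Compound 1 `CCN(Cc1ccccc1)Cc1nc2ccccc2c(-c2ccccc2)c1C(=O)N(CC)CC` gives 373 nM in an assay on brain with Translocator protein (Rattus norvegicus) as the target; a lower number here means a stronger inhibitor, a higher number a weaker inhibitor.
Compound 2 `CCOC(=O)c1c(CN2CCc3ccccc3C2)nc2ccccc2c1-c1ccccc1` gives 1190 nM in this assay.
Compound 3 `CCCNC(=O)c1c(CN(CC)Cc2ccccc2)nc2ccccc2c1-c1ccccc1` gives 872 nM in this assay.

Among these three numbers compound 3 stands second highest. Its nearest neighbour is compound 2, whose number lies within the scatter of that of compound 3, so no order can be read between them. Among the measured compounds shown here, compound 1 lies furthest away, and the single step that joins it to compound 3 is a 2.3-fold higher number from compound 1 to compound 3 (0.37 log units; beyond the scatter), a modest worsening that goes beyond the scatter.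

Compound 4 `CCCN(CCC)C(=O)c1c(CN(CC)Cc2ccccc2)nc2ccccc2c1-c1ccccc1` has not yet been measured. It differs from compound 3 in one place: propyl in place of hydrogen on an amide-type nitrogen. In the words of the wider cut, propylamino becomes dipropylamino. For the measured compounds named here, this is the only measured step that bears on the change, since it also concerns the substitution on the amide-type nitrogen: it ran from a disubstituted amide to a monosubstituted one and raised the number, so the present change, which returns to a disubstituted amide, is expected to lower it by a comparable, modest amount. Compound 4 is therefore expected to give about 380 nM in this assay, with a range from 160 nM to 900 nM. That estimate means a 2.3-fold lower number from compound 3 to compound 4 (0.36 log units; beyond the scatter), which is expected to fall beyond the scatter.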

Compound 4, half-maximal inhibitory concentration: 456 nM
Estimate against measurement, compound 4: 1.2-fold (0.08 log units) below; low and high end bracket the measured number.
By their numbers in this assay, from the lowest: compounds 1, 4, 3 and 2 (each within the scatter of the next, the first and the last beyond it).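

In this assay the added propyl on the amide-type nitrogen gives a 1.9-fold lower number from compound 3 to compound 4 (0.28 log units; within the scatter), so this one change cannot by itself be read as a gain, even though the earlier step from the diethylamino amide to the propylamino amide lay beyond the scatter. Among the compounds shown here, the new compound also places a second disubstituted amide beside the first, and with a 1.2-fold higher number from compound 1 to compound 4 (0.09 log units; within the scatter), dipropylamino and diethylamino on the carbonyl carbon cannot be told apart here, while a 2.3-fold higher number from compound 1 to compound 3 (0.37 log units; beyond the scatter) remains the only step at this position that can be read, and compound 4 lies within the scatter of both compound 1 and compound 3. No measurement on hand offers an explanation for these numbers.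

The compounds shown leave open whether the number would stay in the same range with a longer chain such as butyl on the amide-type nitrogen, or with one butyl and one ethyl there. They also leave open how a carboxylic acid in place of the amide would compare with compound 3 and compound 4.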